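The source may hold more compounds than are shown below. What is called first, only, known or untested is meant among the compounds shown, and "the series" means these compounds.

Among the measured compounds shown here, compound 2 `CCCSc1cc(C)c(C(=O)N=C(N)N)cc1S(C)(=O)=O` holds the lowest of the two numbers so far: in a functional assay for inhibition of sodium/hydrogen exchanger (Oryctolagus cuniculus) (a higher number here means a weaker inhibitor, a lower number a stronger inhibitor), compound 2 gives 6.8 nM, and the nearest figure belongs to compound 1 `CCC(C)c1cc(C)c(C(=O)N=C(N)N)cc1S(C)(=O)=O`, which in this assay gives 8 nM. The step of a 1.2-fold lower number from compound 1 to compound 2 (0.07 log units; within the scatter) exchanged a chain for a chain. Compound 3 `Cc1cc(Sc2ccccc2Cl)c(S(C)(=O)=O)cc1C(=O)N=C(N)N` differs from compound 2 by 2-chlorophenyl in place of propyl on a sulfur. For the measured compounds named here, no measured step swaps a chain for an aromatic ring at this sulfur, so the only guide is the flat step from compound 1 to compound 2. Compound 3 is therefore expected to give 10 nM, in the range 3 nM to 35 nM, a step of a 1.5-fold higher number from compound 2 to compound 3 (0.17 log units; within the scatter) that is estimated to stay near the scatter.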

Compound 3, half-maximal inhibitory concentration: 14 nM
Beside the measured number, compound 3's estimate is 1.4-fold (0.15 log units) below it; measured number inside the range.
By their numbers in this assay, from the lowest: compounds 2, 1 and 3 (each within the scatter of the next, the first and the last beyond it).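

In this assay, 2-chlorophenyl in place of propyl on a sulfur gives a 2.1-fold higher number from compound 2 to compound 3 (0.31 log units; beyond the scatter) and so an aromatic ring on this sulfur costs only a modest step. Set against the branched chain, the sulfur-linked 2-chlorophenyl gives a 1.8-fold higher number from compound 1 to compound 3 (0.24 log units; within the scatter) and so leaves compound 3 level with compound 1. Nothing available explains either step. The compounds shown leave open whether the chlorine matters, which a plain phenyl on this sulfur would test, and whether an amine on the same aromatic carbon would keep the number in this range.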